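The compounds below may be only part of what the source reports. "The series", "measured", "known", "first", "only" and "open" are said of these compounds alone.

Measured so far in a functional assay on HepG2 cells (Homo sapiens) for inhibition, read by MTT assay, with a stated time of 48 h; a higher number here means a weaker inhibitor, a lower number a stronger inhibitor:
- compound 1 `COc1ccc(N(C)c2nc(C)nc3ccccc23)cc1[Se]C`: 17 nM
- compound 2 `COc1ccc(N(C)c2nc(C)nc3ccccc23)cc1C(=O)OCCCC[Se]C#N`: 975 nM
- compound 3 `COc1ccc(N(C)c2nc(C)nc3ccccc23)cc1OCC[Se]C#N`: 14 nM

Compound 3, at 14 nM, stands level with compound 1, at 17 nM, since the two differ only within the scatter. Both sit far below compound 2, at 975 nM, so compound 3 belongs to the stronger end of this small set.

The next compound is compound 4 `COc1ccc(N(C)c2nc(C)nc3ccccc23)cc1OCCCC[Se]C#N`. The structural change is a group of 5 heavy atoms (3 carbon, 1 nitrogen, 1 selenium; no ring) in place of a group of 3 heavy atoms (1 carbon, 1 nitrogen, 1 selenium; no ring), on a saturated chain carbon, two bonds along the chain from an oxygen on an aromatic ring, which lengthens the chain and keeps its ether link to the core.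

Among the compounds with values here, three measured steps bear on this, though none changes chain length alone. The step of a 1.2-fold lower number from compound 1 to compound 3 (0.08 log units; within the scatter) shows that a larger group on the core can leave the number unchanged. Against that stand two large steps, a 57-fold higher number from compound 1 to compound 2 (1.76 log units; beyond the scatter) and a 70-fold lower number from compound 2 to compound 3 (1.84 log units; beyond the scatter). Compound 2 carries the same chain end as compound 4, but joined through an ester, so the data cannot separate chain length from the kind of link. Compound 4 should therefore lie nearer compound 3 than compound 2, with some loss possible.

The expected change is a moderate rise, a 2.5-fold higher number from compound 3 to compound 4 (0.40 log units; beyond the scatter). For compound 4 the estimated value is 35 nM, with an expected range of 10 nM to 150 nM.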

Compound 4, half-maximal inhibitory concentration: 6460 nM
Beside the measured number, compound 4's estimate is 180-fold (2.27 log units) below it; measured number above the stated range.
By their numbers in this assay, from the lowest: compounds 3 and 1 (each within the scatter of the next); then compound 2; then compound 4.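

In this assay the step of a 460-fold higher number from compound 3 to compound 4 (2.66 log units; beyond the scatter) shows that this position is far from tolerant of a longer chain, even though the ether link to the core stays in place. The step of a 380-fold higher number from compound 1 to compound 4 (2.58 log units; beyond the scatter) adds that a larger group on the core is not harmless in general: the shorter chain of compound 3 stands level with compound 1, while the longer chain of compound 4 does not. The step of a 6.6-fold higher number from compound 2 to compound 4 (0.82 log units; beyond the scatter) shows that an ether in place of the ester, with the same chain end, does not bring the number back down, so the ester alone cannot account for the weak number of compound 2.

No measurement shown gives a reason for this sharp loss. With only these two ether chains, a chain of intermediate length would be needed to tell a gradual rise from a sudden one, and an amine link in place of the ether would test how much the link matters at this chain length.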